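Swapping Hydroxy for Amino on a Fused Ring

This account rests on a few compounds, and the source may have more. Where it says the series, first, only, none or still open, it means among the compounds named here.

In an in vitro assay on SH-EP1 cells for displacement of a labelled ligand from Neuronal acetylcholine receptor; alpha4/beta2 (Homo sapiens), tested at 5 uM (a lower number here means less inhibition, a higher number more inhibition at the concentration tested (going by the name of the read-out)), three compounds have been measured so far. Compound 1 `O=C1CC(c2cccs2)=NCC2(CN3CCC2CC3)N1` gives 20%, compound 2 `C1=NCC2(CN3CCC2CC3)NC=C1c1ccccc1` gives 6%, and compound 3 `Oc1c(C2=NC3(CN2)CN2CCC3CC2)oc2ccccc12` gives 32%. Compound 3 thus shows the highest inhibition of the three: the nearest number, that of compound 1, lies beyond the usual scatter below it, and the number of compound 2 lies further below still. Compound 4 `Nc1c(C2=NC3(CN2)CN2CCC3CC2)oc2ccccc12` has not yet been measured. It differs from compound 3 in one place: amino in place of hydroxy on an aromatic carbon. Within the data shown here, no measured pair in this set differs only in this way, so the data give no guide to the size of the effect. The step is expected to be a number 2 percentage points lower from compound 3 to compound 4 (within the scatter), staying within the scatter. Compound 4 is therefore estimated to give 30%, with a range from 15% to 48%.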

Compound 4, a percentage reported as inhibition, at one concentration (the size of the read-out at that concentration, not a potency): 9%
For compound 4 the middle estimate is 21 percentage points above the measured one; the measured number lies below the stated range.
By their numbers in this assay, from the lowest: compounds 2 and 4 (each within the scatter of the next); then compound 1; then compound 3.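

Amino in place of hydroxy on this aromatic carbon, next to the ring atom that bears a large group, gives a number 23 percentage points lower from compound 3 to compound 4 (beyond the scatter). So a change of a single heavy atom matters at this position, even though both groups count the same hydrogen-bond donors and acceptors and neither carries a net charge. Nothing measured here gives a reason for the drop. From the compounds shown here alone, whether methoxy or a plain hydrogen at this position would keep the inhibition of compound 3 stays open. So does whether this swap would have a similar effect on another core.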